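A few compounds are considered here, and "the series" means these few. Any claim that something is new, unique, unknown or untested is made for them only; others in the source may bear on it.

Working notes on the series.

Three members of the series have a number in a functional assay on the whole organism (strain Wistar) for inhibition, with Rattus norvegicus as the target, read by paw edema, with a stated time of 30 min, at a dose of 10 mg/kg by the intraperitoneal route; on this read-out higher numbers stand for more inhibition at the one dose given (going by the name of the read-out) and lower numbers for less inhibition. Compound 1 `O=C(N/N=C/c1ccccc1)c1cccnc1Nc1cccc(C(F)(F)F)c1` gives 60.4%. Compound 2 `O=C(N/N=C/c1ccc(O)c(O)c1)c1cccnc1Nc1cccc(C(F)(F)F)c1`, with 3,4-dihydroxyphenyl in place of phenyl on the carbon with a double bond to nitrogen, gives 51.4%, a step of a number 9 percentage points lower from compound 1 to compound 2 (within the scatter). Compound 3 `COc1ccc(/C=N/NC(=O)c2cccnc2Nc2cccc(C(F)(F)F)c2)cc1` gives 50.4%, the smallest of the three numbers, yet its distance to compound 2, a number 1 percentage points lower from compound 2 to compound 3 (within the scatter), and to compound 1, a number 10 percentage points lower from compound 1 to compound 3 (within the scatter), both stay inside the scatter, so no ranking among the three is claimed.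

Compound 4 `CN(C)c1ccc(/C=N/NC(=O)c2cccnc2Nc2cccc(C(F)(F)F)c2)cc1` is not yet measured. The change from compound 3 is dimethylamino in place of methoxy on an aromatic carbon. For the measured compounds named here, the step that bears on it most directly is a number 10 percentage points lower from compound 1 to compound 3 (within the scatter), the only earlier change at the same aromatic carbon, and the other change on that ring, a number 1 percentage points lower from compound 2 to compound 3 (within the scatter), is equally small. Every substitution on this ring so far has moved the read-out by less than the scatter, so no step beyond the scatter is expected in either direction for compound 4, an expected a number 1.6 percentage points higher from compound 3 to compound 4 (within the scatter).

The estimate for compound 4 in this assay is therefore 52%, expected to fall between 40% and 64%.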

Compound 4, a percentage reported as inhibition, in the whole organism at one dose (the size of the read-out at that dose, not a potency): 61.3%
Compound 4: the middle estimate sits 9.3 percentage points below what was measured; the range from low to high includes it.
By their numbers in this assay, from the lowest: compounds 3, 2, 1 and 4 (each within the scatter of the next, the first and the last beyond it).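

For the compounds shown here, the step of a number 10.9 percentage points higher from compound 3 to compound 4 (beyond the scatter) in this assay is the only one so far to pass the scatter, so on the aromatic carbon para to a large group, the exchange of methoxy for dimethylamino is a change this read-out can resolve, which no earlier pair showed. That resolution is confined to this one pair: the step of a number 9.9 percentage points higher from compound 2 to compound 4 (within the scatter) and the step of a number 0.9 percentage points higher from compound 1 to compound 4 (within the scatter) both leave compound 4 unseparated from its neighbours, so dimethylamino cannot be told from hydrogen at this carbon, nor 4-(dimethylamino)phenyl from 3,4-dihydroxyphenyl, and the effect reads as much as a feature of methoxy as of dimethylamino. Nothing in the data shown explains why this exchange registers when the others do not.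

Open, as far as these compounds go, is whether other groups at this carbon, such as a primary amine, a diethylamino group or a carboxylic acid, would stand with methoxy or with dimethylamino. Also open, from the compounds shown here alone, is whether the gap between this pair would persist at a dose other than the single one given, since one dose gives no potency.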